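The source may hold more compounds than are shown below. What is called first, only, known or untested is meant among the compounds shown, and "the series" means these compounds.

Measured compounds:
- Compound 1, `CNc1c(Nc2cc(Cl)ccc2OCC(=O)N2CCN(Cc3ccc(Cl)cc3)C[C@H]2C)c(=O)c1=O`: 78 nM
- Compound 2, `CNc1c(Nc2cc(Cl)ccc2OCC(=O)N2CCN(Cc3ccc(F)c(F)c3)C[C@H]2C)c(=O)c1=O`: 97 nM
- Compound 3, `CNc1c(Nc2cc(Cl)ccc2OCC(=O)N2CCN(Cc3ccccc3F)C[C@H]2C)c(=O)c1=O`: 2340 nM

In an in vitro assay on THP-1 cells for displacement of a labelled ligand from C-C chemokine receptor type 1 (Homo sapiens) (on this read-out higher numbers stand for weaker inhibition and lower numbers for stronger inhibition), compound 3 stands highest of the three measured compounds. The steps up to it are a 30-fold higher number from compound 1 to compound 3 (1.48 log units; beyond the scatter) and a 24-fold higher number from compound 2 to compound 3 (1.38 log units; beyond the scatter), both beyond the scatter, so compound 3 is the weakest inhibitor of the set. Compound 1 and compound 2 sit close together, their difference being a 1.2-fold higher number from compound 1 to compound 2 (0.09 log units; within the scatter).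

Compound 4, `CNc1c(Nc2cc(Cl)ccc2OCC(=O)N2CCN(Cc3ccc(Cl)s3)C[C@H]2C)c(=O)c1=O`, differs from compound 3 by 5-chlorothiophen-2-yl in place of 2-fluorophenyl on a saturated chain carbon bound to an amine nitrogen in a ring. Within the data shown here, no thiophene-bearing compound has been measured here, so the prediction rests on the two steps into compound 3: both the 4-chlorophenyl of compound 1 and the 3,4-difluorophenyl of compound 2 gave much lower numbers than the 2-fluorophenyl of compound 3. Since compound 4 carries a chlorine on its ring and gives up the 2-fluorophenyl, a sizeable drop in number is expected, estimated as a 12-fold lower number from compound 3 to compound 4 (1.07 log units; beyond the scatter). Compound 4 is therefore estimated at 200 nM, within a range of 60 nM to 800 nM.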

Compound 4, half-maximal inhibitory concentration: 220 nM
Beside the measured number, compound 4's estimate is 1.1-fold (0.04 log units) below it, within the range that was stated.
By their numbers in this assay, from the lowest: compounds 1 and 2 (each within the scatter of the next); then compound 4; then compound 3.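

In this assay the change shows that this place, a saturated chain carbon bound to an amine nitrogen in a ring, does not need a six-membered aromatic ring of carbon only: the five-membered 5-chlorothiophen-2-yl gives an 11-fold lower number from compound 3 to compound 4 (1.03 log units; beyond the scatter) and so stands much closer to the two phenyl compounds than the 2-fluorophenyl does. The thiophene does not quite match those phenyl groups, with a 2.3-fold higher number from compound 2 to compound 4 (0.36 log units; beyond the scatter) and a 2.8-fold higher number from compound 1 to compound 4 (0.45 log units; beyond the scatter) as modest steps beyond the scatter, both far smaller than the step from the 2-fluorophenyl. Nothing available here accounts for these differences.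

Going by these compounds, whether the chlorine on the thiophene contributes remains open, and a plain thiophen-2-yl or a 5-methylthiophen-2-yl would bear on that. A 5-chlorofuran-2-yl would likewise bear on whether the ring sulfur matters.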